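The source may hold more compounds than are shown below. What is called first, only, known or untested is meant among the compounds shown, and "the series" means these compounds.

Results so far in an ADME assay for permeability, using PAMPA; a higher number here means that the compound crosses the layer faster, a lower number that the compound crosses the layer more slowly
- compound 1 `O=C(Nc1ccccc1Cl)c1cc(Cl)ccc1O` - 118 10^-6 cm/s
- compound 2 `O=C(Nc1ccc(F)cc1Cl)c1cc(Cl)ccc1O` - 50.5 10^-6 cm/s
- compound 3 `O=C(Nc1ccc(F)cc1F)c1cc(Cl)ccc1O` - "not determined" (no result reported)

Compound 2 (50.5 10^-6 cm/s) holds the lower of the two numbers available, under compound 1 (118 10^-6 cm/s) by more than the usual scatter, while compound 3 gave no number to compare. Compound 4 `CC(=O)Nc1ccc(NC(=O)c2cc(Cl)ccc2O)c(Cl)c1` has not been measured yet. It keeps the core of compound 2 but carries acetamido in place of fluoro on an aromatic carbon.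

Among the compounds with values here, only one measured step bears on this change: a 2.3-fold lower number from compound 1 to compound 2 (0.37 log units; beyond the scatter) with fluoro in place of hydrogen on an aromatic carbon. Within the data shown here, that modest step involves the same fluoro group that now leaves, but it swaps a single atom, and no measured compound carries acetamido. Its size is therefore only a loose guide. A lower number in this assay is expected, by more than that one step showed, though this rests on very thin evidence. The expected change is a 3.4-fold lower number from compound 2 to compound 4 (0.53 log units; beyond the scatter) as an estimate only. For compound 4 the estimated value is 15 10^-6 cm/s with an expected range from 4 10^-6 cm/s to 50 10^-6 cm/s on this slim basis.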

Compound 4, apparent permeability: 87 10^-6 cm/s
Compound 4: middle estimate off by 5.8-fold (0.76 log units), on the low side, outside the stated range (above it).
By their numbers in this assay, from the lowest: compounds 2, 4 and 1 (each within the scatter of the next, the first and the last beyond it).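

In this assay, acetamido in place of fluoro on this aromatic carbon gives a 1.7-fold higher number from compound 2 to compound 4 (0.24 log units; within the scatter) and acetamido in place of hydrogen gives a 1.4-fold lower number from compound 1 to compound 4 (0.13 log units; within the scatter) so neither swap separates compound 4 from its neighbour by more than repeat measurements would. Until now this position had been probed only with a single fluorine atom, and that small change gave a 2.3-fold lower number from compound 1 to compound 2 (0.37 log units; beyond the scatter) while compound 4 shows that the same carbon can carry acetamido, with its four heavy atoms, its hydrogen-bond donor and its hydrogen-bond acceptor, and still read within the scatter of both compound 1 and compound 2. The compounds shown carry no measurement that explains this outcome.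

Going by these compounds, whether other groups at this carbon would also read within the scatter of compound 1 and compound 2 stays open, for example an amine, a carboxylic acid or a longer chain. Also open, on these data alone, is whether acetamido would give the same picture if the chloro group on this ring were replaced by a methyl group.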